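This account rests on a few compounds, and the source may have more. Where it says the series, first, only, none or still open, it means among the compounds named here.

Working notes on the series, read in a functional assay on MCF7 cells (Homo sapiens) for antiproliferative activity, read by MTT assay, with a stated time of 48 h; on this read-out higher numbers stand for weaker inhibition and lower numbers for stronger inhibition. Compound 1 (`Brc1ccc2[nH]c(-c3cn(-c4ccccc4)nc3-c3ccccc3)nc2c1`) gives 830 nM, and compound 2 (`Cc1ccc2[nH]c(-c3cn(-c4ccccc4)nc3-c3ccccc3)nc2c1`) gives 5940 nM. Compound 3 (`Cc1cc2nc(-c3cn(-c4ccccc4)nc3-c3ccccc3)[nH]c2cc1C`) gives > 50000 nM, which is a limit of the assay and not a number. That leaves compound 3 at the limit of > 50000 nM in this assay, at which 1 of the 3 values shown sits.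

Compound 4 (`COc1ccc(-c2nn(-c3ccccc3)cc2-c2nc3cc(C)c(C)cc3[nH]2)cc1`) differs from compound 3 by methoxy in place of hydrogen on an aromatic carbon, or phenyl to 4-methoxyphenyl. Neither measured step touches that phenyl, so the two steps offer a guide to size only. They are a 7.2-fold higher number from compound 1 to compound 2 (0.85 log units; beyond the scatter) and an at least 8.4-fold higher number from compound 2 to compound 3 (0.92 log units; beyond the scatter), and both were made elsewhere on the shared core. A step of similar size is therefore expected in this assay, towards a lower number, though the direction is weakly supported and a second limit remains quite possible. The expected move is an at least 2.0-fold lower number from compound 3 to compound 4 (0.30 log units; that floor lies within the scatter). The estimate for compound 4 is 25000 nM, with an expected range of 5000 nM to 80000 nM.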

Compound 4, half-maximal inhibitory concentration: 12800 nM
For compound 4 the middle estimate is 2.0-fold (0.29 log units) above the measured one; the range from low to high includes it.
By their numbers in this assay, from the lowest: compound 1; then compound 2; then compound 4. At a limit, above all of these: compound 3.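

In this assay, phenyl to 4-methoxyphenyl is the first change shown on this phenyl of the shared core, and it gives an at least 3.9-fold lower number from compound 3 to compound 4 (0.59 log units; beyond the scatter). Methoxy at this aromatic carbon, para to a large group, therefore moves the series from a limit to a measured number, which the two earlier steps, both made elsewhere on the shared core, could not show for this position. The size of the step remains a floor, since compound 3 is held only as a limit: the limit of > 50000 nM in this assay, at which 1 of the 4 values shown sits.

As far as these compounds go, whether this step belongs to methoxy itself or would also follow from another group at this place stays open; a hydroxyl, an amine or a chloro group on the same phenyl would help to separate the two. Among the compounds shown here, also open is whether methoxy gives a step of similar size alongside the bromo of compound 1 or the single methyl of compound 2.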